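A few compounds are considered here, and "the series" means these few. Any claim that something is new, unique, unknown or untested is made for them only; others in the source may bear on it.

Compound 1 `NC(=O)CCCN(Cc1cccc(C(N)=O)c1)C[C@H]1O[C@@H](n2cnc3c(N)ncnc32)[C@H](O)[C@@H]1O` in an assay on cells for inhibition of Nicotinamide N-methyltransferase (Homo sapiens), with stated times of 10 min and 30 min (a lower number here means a stronger inhibitor, a higher number a weaker inhibitor), gives > 250000 nM, which is a limit of the assay rather than a number.
Compound 2 `NC(=O)CCCN(Cc1cccc(C(=O)O)c1)C[C@H]1O[C@@H](n2cnc3c(N)ncnc32)[C@H](O)[C@@H]1O` in this assay gives > 250000 nM, again a limit rather than a number.

Among the compounds with values here, compound 2 therefore stands at the edge of what this assay can report, with no measured number of its own, and the only neighbour shown sits at the same place. Within the data shown here, the single step between these two, a step that the two limits leave unreadable from compound 1 to compound 2, is unreadable, since both ends are limits; what can be said is given by the limit of > 250000 nM in this assay, at which 2 of the 2 values shown sit.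

Compound 3 `NC(=O)CCCN(Cc1ccc2ccccc2c1)C[C@H]1O[C@@H](n2cnc3c(N)ncnc32)[C@H](O)[C@@H]1O` differs from compound 2 in one place: naphthalen-2-yl in place of 3-carboxyphenyl on a saturated chain carbon bound to an amine nitrogen. The carboxyl and its hydroxyl are gone, and a second fused aromatic ring is added in their place. No measured step bears on this change, so nothing of size or direction can be read from the numbers shown. The expectation for the step from compound 2 to compound 3 is an at least 3.1-fold lower number from compound 2 to compound 3 (0.49 log units; beyond the scatter), with wide uncertainty. Compound 3 is therefore estimated at 80000 nM in this assay, expected to fall between 5000 nM and 500000 nM.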

Compound 3, half-maximal inhibitory concentration: 112000 nM
Compound 3: middle estimate off by 1.4-fold (0.15 log units), on the low side, and the stated range covers the measured number.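

Among the three compounds, only compound 3 gives a real number in this assay, 112000 nM. A change at this place, on a saturated chain carbon bound to an amine nitrogen, can therefore move the read-out off the limit. Naphthalen-2-yl in place of 3-carboxyphenyl gives an at least 2.2-fold lower number from compound 2 to compound 3 (0.34 log units; beyond the scatter), and the same group in place of 3-carbamoylphenyl gives an at least 2.2-fold lower number from compound 1 to compound 3 (0.34 log units; beyond the scatter); each of these is only a minimum size, and the true size of either step stays unknown. The two compounds with a substituted single ring remain at the edge of what can be reported: the limit of > 250000 nM in this assay, at which 2 of the 3 values shown sit.

The change removes the carboxyl or carbamoyl group and adds a second fused ring in one move, so the compounds shown cannot tell which of the two matters, and a plain phenyl ring at this place would separate them. They also leave open whether naphthalen-1-yl, or a two-ring group containing a ring nitrogen such as quinolinyl, would give a lower number than compound 3.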